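Halogen swap on a bicyclic headgroup: compound 2 to compound 4

The compounds below may be only part of what the source reports. "The series", "measured", "known", "first", "only" and "open" are said of these compounds alone.

Measured compounds:
compound 1 `COc1nc(OC)c2c(ccn2C/C=C2\OC(=O)C(OCc3ccccc3)=C2OCc2ccccc2)n1` — 4700 nM
compound 2 `O=C1NC(O)(CCn2cnc3ccnc(Cl)c32)C(OCc2ccccc2)=C1OCc1ccccc1` — "not determined" (no result reported)
compound 3 `O=C1O/C(=C\Cn2cnc3c(Cl)c(F)nc(F)c32)C(OCc2ccccc2)=C1OCc1ccccc1` — "not determined" (no result reported)

In a functional assay on L1210/0 cells (Mus musculus) for antiproliferative activity, read by MTT assay, with a stated time of 72 h (on this read-out higher numbers stand for weaker inhibition and lower numbers for stronger inhibition), only compound 1 carries a number, giving 4700 nM. Compound 2 stands without any value there, and compound 3 likewise has none, so nothing measured sets the footing for the step. Compound 4 `O=C1NC(O)(CCn2cnc3cncc(Br)c32)C(OCc2ccccc2)=C1OCc1ccccc1` differs from compound 2 by a group of 10 heavy atoms (6 carbon, 3 nitrogen, 1 bromine; one five-membered aromatic ring with 2 hetero atoms, one six-membered aromatic ring with 1 hetero atom) in place of a group of 10 heavy atoms (6 carbon, 3 nitrogen, 1 chlorine; one five-membered aromatic ring with 2 hetero atoms, one six-membered aromatic ring with 1 hetero atom), on a saturated chain carbon, two bonds along the chain from a saturated ring carbon. Among the measured compounds shown here, no measured pair tells the effect of such a swap here. Given that both groups keep the same count of heavy atoms, rings, donors and acceptors, a step in this assay no larger than the usual scatter is expected, in no particular direction. With compound 1 as the only anchor, compound 4 is expected to give about 5000 nM, within a wide range from 1000 nM to 30000 nM.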

Compound 4, half-maximal inhibitory concentration: 50000 nM
The estimate for compound 4 lay 10-fold (1.00 log units) below the measured number; the whole stated range lies below it.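

Among the compounds shown here, compound 2 carries no number in this assay, so no step to compound 4 can be read. The compounds shown leave open what the bromine-for-chlorine group swap does to the read-out. Nothing shown offers an explanation for the value of compound 4.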